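The source may report more compounds than this note shows. Statements on the series, on what has been measured and on what is new or still open speak of the compounds shown alone.

Measured in an ADME assay on microsomes from liver (Rattus norvegicus) for metabolic stability, read by LC-MS, using NADPH, with stated times of 5 min and 60 min, tested at 4 uM; a higher number here means that more of the compound is left, a lower number that less of the compound is left:
- Compound 1 `CC1=C(c2nc(-c3ccc(C#N)cc3)cs2)C(c2cc3ccccc3n2C)NC(=O)N1`: 62.9%
- Compound 2 `CC1=C(c2nc(-c3ccc(C#N)cc3)cs2)C(c2ccc(Br)nc2)NC(=O)N1`: 67.6%
- Compound 3 `COc1ccc(C2NC(=O)NC(C)=C2c2nc(-c3ccc(C#N)cc3)cs2)cn1`: 69.4%

Compound 3 stands level with the other two compounds, since its number lies within the scatter of both. The steps are a number 1.8 percentage points higher from compound 2 to compound 3 (within the scatter) and a number 6.5 percentage points higher from compound 1 to compound 3 (within the scatter). The remaining step is a number 4.7 percentage points higher from compound 1 to compound 2 (within the scatter).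

The next compound is compound 4 `COc1ccc(C2NC(=O)NC(C)=C2c2nc(-c3ccc(C#N)cc3)cs2)cc1`, which has 4-methoxyphenyl in place of 6-methoxypyridin-3-yl on a saturated ring carbon. All three measured steps fall at this same carbon or on the group it carries, and none leaves the scatter. None of them makes this exact exchange, however, so they bear on it only indirectly. Going by the values given here, compound 1, the only measured compound without a pyridinyl group, gives 62.9%, which suggests at most a small downward move in this assay. The estimated change is a number 6.4 percentage points lower from compound 3 to compound 4 (within the scatter). For compound 4 the estimate is 63%, with an expected range from 48% to 75%.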

Compound 4, percent of the compound remaining: 63.2%
The estimate for compound 4 lay 0.2 percentage points below the measured number, within the range that was stated.
By their numbers in this assay, from the lowest: compounds 1, 4, 2 and 3 (each within the scatter of the next).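

In this assay, going by these compounds alone, the exchange of 6-methoxypyridin-3-yl for 4-methoxyphenyl gives the first direct reading of a ring of carbon only against a pyridinyl ring with the methoxy kept, and the step is a number 6.2 percentage points lower from compound 3 to compound 4 (within the scatter). The comparisons with the other two groups at this saturated ring carbon read a number 4.4 percentage points lower from compound 2 to compound 4 (within the scatter) and a number 0.3 percentage points higher from compound 1 to compound 4 (within the scatter), so all four groups now lie within the scatter of one another and this position shows no separation among them. Nothing available explains these numbers.

The compounds shown leave open how an aliphatic amine or a longer chain on this carbon would read in this assay, since each of the four carries an aromatic ring there. As far as these compounds go, they also all keep the nitrile, so the reading of a carboxylic acid in its place remains open.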